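A few compounds are considered here, and "the series" means these few. Any claim that something is new, unique, unknown or untested is made for them only; others in the source may bear on it.

Measured compounds:
compound 1, `Cn1cnc(C(=O)NNC(=O)COc2ccc(C(=O)c3ccccc3)cc2)c1`: 29600 nM
compound 2, `Cn1cnc(C(=O)NNC(=O)COc2c(F)cc(C(=O)c3ccc(Cl)cc3)cc2Cl)c1`: 47300 nM
compound 3, `O=C(COc1ccc(C(=O)c2ccccc2)cc1)NNC(=O)c1ccc(=O)oc1`: 92900 nM

All three were read in a functional assay on MCF7 cells (Homo sapiens) for cytotoxicity, read by trypan blue exclusion, with a stated time of 48 h; on this read-out higher numbers stand for weaker inhibition and lower numbers for stronger inhibition. Compound 1 and compound 3 share a core and differ in one place: a group of 7 heavy atoms (5 carbon, 2 oxygen; one six-membered aromatic ring with 1 hetero atom) in place of a group of 6 heavy atoms (4 carbon, 2 nitrogen; one five-membered aromatic ring with 2 hetero atoms), on a carbonyl carbon. That change gave a 3.1-fold higher number from compound 1 to compound 3 (0.50 log units; beyond the scatter). Compound 2 carries a different core, and how the core of compound 2 differs from that of compound 1 is not broken down here. In this assay compound 2 gives 47300 nM, which lies within the scatter of both compound 1 and compound 3, so those two pairs allow no ordering.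

Compound 4, `O=C(COc1c(F)cc(C(=O)c2ccc(Cl)cc2)cc1Cl)NNC(=O)c1ccc(=O)oc1`, is not yet measured. It stands to compound 2 as compound 3 stands to compound 1: a group of 7 heavy atoms (5 carbon, 2 oxygen; one six-membered aromatic ring with 1 hetero atom) in place of a group of 6 heavy atoms (4 carbon, 2 nitrogen; one five-membered aromatic ring with 2 hetero atoms), on a carbonyl carbon. The place is the same word for word in both cases, so this is the same change, seen so far only once. The step expected in this assay is a 2.9-fold higher number from compound 2 to compound 4 (0.46 log units; beyond the scatter), set beside the measured step because a 3.1-fold higher number from compound 1 to compound 3 (0.50 log units; beyond the scatter) was observed, with wide bounds given the single occurrence. Compound 4 is expected to give about 135000 nM in this assay. The expected range for compound 4 runs from 50000 nM to 350000 nM.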

Compound 4, half-maximal inhibitory concentration: 90600 nM
For compound 4 the middle estimate is 1.5-fold (0.17 log units) above the measured one; measured number inside the range.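

In this assay, going by these compounds alone, putting the group with a six-membered aromatic ring in place of 1-methyl-1H-imidazol-4-yl, on a carbonyl carbon, gave a 1.9-fold higher number from compound 2 to compound 4 (0.28 log units; within the scatter) and so allows no ordering of that pair on its own. Set beside the earlier step, the second occurrence does not differ from the first: the same change on two cores in this assay, a 3.1-fold higher number (0.50 log units; beyond the scatter) from compound 1 to compound 3 and a 1.9-fold higher number (0.28 log units; within the scatter) from compound 2 to compound 4, 1.6-fold (0.21 log units) apart, within the scatter of two such steps. The change therefore carries from the core of compound 1 to the core of compound 2 within what this read-out can resolve, but that agreement rests on two cores only and does not establish a shift beyond the scatter on the core of compound 2, nor explain the step.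

From the compounds shown here alone, whether the same agreement holds for other groups on this carbonyl carbon, such as a phenyl ring, a primary amine or a longer alkyl chain, remains open. Also open is what the chloro and fluoro groups of compound 2 each contribute, as no compound shown carries only one of them.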